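The source may hold more compounds than are shown below. What is called first, only, known or untested is meant among the compounds shown, and "the series" means these compounds.

Within the data shown here, in a functional assay on A549 cells (Homo sapiens) for cytotoxicity, read by LDH release, with a stated time of 48 h (a higher number here means a weaker inhibitor, a lower number a stronger inhibitor), compound 1 (`O=C(COc1c(F)cc(C(=O)c2ccc(F)cc2)cc1Cl)NNC(=O)c1ccc(=O)oc1`) gives 60200 nM and compound 2 (`Cn1cnc(C(=O)NNC(=O)COc2c(F)cc(C(=O)c3ccc(F)cc3)cc2Cl)c1`) gives 40700 nM, so compound 2 stands within the scatter of the only other measured value. Among the measured compounds shown here, the single measured step, a 1.5-fold lower number from compound 1 to compound 2 (0.17 log units; within the scatter), exchanges one aromatic ring group for another on a carbonyl carbon and leaves the 4-fluorophenyl untouched, so it bears only indirectly on the next change. Compound 3 (`Cn1cnc(C(=O)NNC(=O)COc2c(F)cc(C(=O)c3ccc(Cl)cc3)cc2Cl)c1`) keeps everything in compound 2 except that 4-fluorophenyl becomes 4-chlorophenyl: chloro in place of fluoro on an aromatic carbon. For the measured compounds named here, no measured step tests this exchange, so the expectation rests on compound 2 at 40700 nM, and no step beyond the scatter is expected in this assay. The expected size is a 1.1-fold lower number from compound 2 to compound 3 (0.05 log units; within the scatter). For compound 3 the estimated value is 36000 nM, with an expected range of 15000 nM to 85000 nM.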

Compound 3, half-maximal inhibitory concentration: 45800 nM
Compound 3: the middle estimate sits 1.3-fold (0.10 log units) below what was measured, and the stated range covers the measured number.
By their numbers in this assay, from the lowest: compounds 2, 3 and 1 (each within the scatter of the next).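

In this assay, chloro in place of fluoro on an aromatic carbon, para to a large group, gives a 1.1-fold higher number from compound 2 to compound 3 (0.05 log units; within the scatter). Among these compounds, this is the first reading at this position: the two halogens cannot be told apart here, whereas the earlier step concerned only the aromatic ring group on a carbonyl carbon at another part of the molecule. No measurement bearing on this result is available.

As far as these compounds go, whether any group at this position can move the number beyond the scatter stays open, and an amine, a carboxylic acid or a methoxy group in place of the halogen would test that. Both steps shown lie within the scatter, so it also remains open which part of the shared core, if any, governs the numbers in this assay.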